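A few compounds are considered here, and "the series" means these few. Any claim that something is new, unique, unknown or untested is made for them only; others in the source may bear on it.

In an assay on NIH3T3 cells for inhibition of Sonic hedgehog protein (Mus musculus), read by a luciferase reporter, with a stated time of 48 h (on this read-out lower numbers stand for stronger inhibition and higher numbers for weaker inhibition), compound 2 `Cc1cc(-c2ccc(OC(F)(F)F)cc2)nc(Nc2ccc(C(=O)Nc3c(C)cccc3C)cc2)n1` gives 1.4 nM, the lowest of the two numbers recorded. Compound 1 `Cc1cnc(Nc2ccc(C(=O)Nc3c(C)cccc3C)cc2)nc1-c1ccc(OC(F)(F)F)c(F)c1` gives 159 nM, a higher number by a margin beyond the usual scatter. Compound 3 `CCCc1cc(-c2ccc(OC(F)(F)F)cc2)nc(Nc2ccc(C(=O)Nc3c(C)cccc3C)cc2)n1` has not yet been measured. It differs from compound 2 by ethyl in place of hydrogen on a saturated chain carbon bound to an aromatic carbon. Going by the values given here, no measured pair shows this change, and its effect is unknown; the step in this assay is expected to be small, likely within the scatter, perhaps toward a slightly higher number. The estimated step is a 1.8-fold higher number from compound 2 to compound 3 (0.25 log units; within the scatter). Compound 3 is therefore expected to give 2.5 nM, within 0.7 nM to 10 nM.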

Compound 3, half-maximal inhibitory concentration: 0.8 nM
Compound 3: middle estimate off by 3.1-fold (0.49 log units), on the high side; low and high end bracket the measured number.
By their numbers in this assay, from the lowest: compounds 3 and 2 (each within the scatter of the next); then compound 1.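

Ethyl in place of hydrogen on a saturated chain carbon bound to an aromatic carbon gives a 1.8-fold lower number from compound 2 to compound 3 (0.24 log units; within the scatter) in this assay and so gives the first reading at this place. Methyl and propyl here read alike, since compound 3 stays within the scatter of compound 2. Nothing available bears on why the two compounds read alike.

The compounds shown leave open whether a longer chain, a branched chain such as isopropyl, an amine or a carboxylic acid at this place would also stay within the scatter of compound 2.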